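Amide variation on a chromene scaffold: from dimethylamide to primary amide

A few compounds are considered here, and "the series" means these few. Any claim that something is new, unique, unknown or untested is made for them only; others in the source may bear on it.

The series shares one core, carried by compound 1 `COc1ccc2c(c1)OC(c1cc(OC)c(OC)c(OC)c1)C(C(=O)OCCc1ccccc1)=C2`, compound 2 `COc1ccc2c(c1)OC(c1cc(OC)c(OC)c(OC)c1)C=C2` and compound 3 `COc1ccc2c(c1)OC(c1cc(OC)c(OC)c(OC)c1)C(C(=O)N(C)C)=C2`. In a functional assay for inhibition of nuclear factor NF-kappa-B complex (Homo sapiens) (a lower number here means a stronger inhibitor, a higher number a weaker inhibitor), compound 1 gives 16200 nM. In this assay compound 2 gives 17700 nM, and a 1.1-fold higher number from compound 1 to compound 2 (0.04 log units; within the scatter). For compound 3 the result in this assay is only a limit, > 50000 nM, so compound 3 stands at the limit of > 50000 nM in this assay, at which 1 of the 3 values shown sits, and no number is known for it. The measured steps toward it are an at least 3.0-fold higher number from compound 1 to compound 3 (0.48 log units; beyond the scatter) and an at least 2.8-fold higher number from compound 2 to compound 3 (0.45 log units; beyond the scatter).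

Compound 4 `COc1ccc2c(c1)OC(c1cc(OC)c(OC)c(OC)c1)C(C(N)=O)=C2` differs from compound 3 by amino in place of dimethylamino on a carbonyl carbon. Among the compounds with values here, no measured step exchanges one amide substituent for another; the two steps into compound 3 both end at the limit, which leaves the starting point of this step unknown. The expected step of a number no higher from compound 3 to compound 4 (the limit leaves the size open) is therefore set at no change beyond the scatter, and compound 4 is estimated at 50000 nM in this assay, with a range from 15000 nM to 150000 nM.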

Compound 4, half-maximal inhibitory concentration: > 50000 nM
Compound 4: only a limit was reported; the forecaster's own chance of this, stated with the estimate: 60%; the middle value lies on the limit itself.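

In this assay compound 4 gives > 50000 nM, which is a limit and not a number. Carbamoyl on the double-bonded ring carbon, like dimethylcarbamoyl there, gives a result beyond the scatter on the weak side of both the hydrogen and the phenethyl ester, with an at least 2.8-fold higher number from compound 2 to compound 4 (0.45 log units; beyond the scatter) and an at least 3.0-fold higher number from compound 1 to compound 4 (0.48 log units; beyond the scatter). Removing the two methyl groups therefore yields no measurable value, and the steps between the two limits cannot be read, so neither amide can be ranked against the other: the limit of > 50000 nM in this assay, at which 2 of the 4 values shown sit.

The compounds shown leave open whether any amide on this carbonyl carbon can reach a measurable value in this assay, and whether the loss comes with the amide link or with the missing phenethyl chain. A phenethyl amide would set the amide link directly against compound 1, and a carboxylic acid would show the carbonyl carbon without either substituent.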